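Second methoxy group on a chalcone: expected cell tolerance

The source may hold more compounds than are shown below. What is called first, only, known or untested is meant among the compounds shown, and "the series" means these compounds.

Measured compounds in an ADME assay on Vero cells (Chlorocebus sabaeus) for cytotoxicity, read by MTT assay, with a stated time of 72 h; a higher number here means that more compound is tolerated, a lower number that less compound is tolerated:
- compound 1 `CCCOc1ccc(C(=O)/C=C/c2ccc(C(=O)Nc3cccc(-c4cc(C(=O)OC)no4)c3)cc2)cc1` gives > 40 ug/mL, a limit of the assay.
- compound 2 `COC(=O)c1cc(-c2cccc(NC(=O)c3ccc(/C=C/C(=O)c4ccc(Br)cc4)cc3)c2)on1` gives > 20 ug/mL, a limit of the assay.
- compound 3 `COC(=O)c1cc(-c2cccc(NC(=O)c3ccc(/C=C/C(=O)c4ccc(OC)cc4)cc3)c2)on1` gives > 10 ug/mL, a limit of the assay.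

None of these three values is a number; each is a limit, so compound 3 stands only at a limit among the values shown, and the two other values are limits as well. The steps between the measured compounds cannot be read: a step that the two limits leave unreadable from compound 1 to compound 2, a step that the two limits leave unreadable from compound 1 to compound 3 and a step that the two limits leave unreadable from compound 2 to compound 3. Going by the values given here, the evidence is therefore only that compound 3 sits at the limit of > 10 ug/mL in this assay, at which 1 of the 3 values shown sits, compound 2 at the limit of > 20 ug/mL in this assay, at which 1 of the 3 values shown sits, and compound 1 at the limit of > 40 ug/mL in this assay, at which 1 of the 3 values shown sits.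

Compound 4 `COC(=O)c1cc(-c2cccc(NC(=O)c3ccc(/C=C/C(=O)c4ccc(OC)c(OC)c4)cc3)c2)on1` differs from compound 3 by methoxy in place of hydrogen on an aromatic carbon. Among the compounds with values here, no measured step bears on this change, so no size or direction of step in this assay can be read; the expectation is a value close to that of compound 3, most likely again reported only as a limit.

Compound 4 is expected to give 25 ug/mL in this assay, between 10 ug/mL and 60 ug/mL. From compound 3 this estimate means a step that the limit leaves unreadable from compound 3 to compound 4, which is expected to stay within the usual scatter.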

Compound 4, half-maximal cytotoxic concentration: > 50 ug/mL
Compound 4: a limit, no number (the forecaster's own chance of this, stated with the estimate: 70%); middle value at least 2.0-fold (0.30 log units) away from the limit.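

Compound 4 gives > 50 ug/mL, which is a limit of the assay and not a number. Going by these compounds alone, the values of compound 1, compound 2 and compound 3 are limits as well, and no step to compound 4 can be read. In this assay, the compounds shown leave open the concentration at which any of them harms the cells, and whether the added methoxy of compound 4 changes it at all.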